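A few compounds are considered here, and "the series" means these few. Any claim that something is new, unique, unknown or untested is made for them only; others in the source may bear on it.

Measured in an ADME assay (liver, Mus musculus) for metabolic stability, using microsomes; a lower number here means that the compound disappears faster, a higher number that the compound lasts longer:
- compound 1 `CCc1nc2cc(Cl)ccn2c1C(=O)NCc1ccc(-c2ccc(C)cc2)cc1`: 0.385 h
- compound 2 `CCc1nc2cc(Cl)ccn2c1C(=O)NCc1ccc(-c2ccc(Cl)cc2)cc1`: > 1 h
- compound 3 `CCc1nc2cc(Cl)ccn2c1C(=O)NCc1ccc(-c2ccc[nH]2)cc1`: 0.18 h

The entry for compound 2, > 1 h, is a limit of the assay and not a number.

Compound 3, at 0.18 h, stands lowest of the set in this assay, and its steps to both others lie beyond the scatter. The next step leads to compound 4 `CCc1nc2cc(Cl)ccn2c1C(=O)NCc1ccc(N2CCCCC2)cc1`, with piperidin-1-yl in place of 1H-pyrrol-2-yl on an aromatic carbon.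

Two measured steps change this same place: a 2.1-fold lower number from compound 1 to compound 3 (0.33 log units; beyond the scatter) and an at least 5.5-fold lower number from compound 2 to compound 3 (0.74 log units; beyond the scatter). Both end at the 1H-pyrrol-2-yl and both go down, the second being measured against a limit. Neither tests a non-aromatic ring, so they are only a loose guide. The step of an at least 2.5-fold higher number from compound 1 to compound 2 (0.41 log units; beyond the scatter) changes a different place and bears little on this one.

A small rise is therefore expected, probably not beyond the scatter: the expected step is a 1.4-fold higher number from compound 3 to compound 4 (0.14 log units; within the scatter). For compound 4 the estimate is 0.25 h, with an expected range from 0.1 h to 0.6 h.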

Compound 4, half-life: 0.0383 h
Estimate against measurement, compound 4: 6.5-fold (0.81 log units) above; measured number below the stated range.
By their numbers in this assay, from the lowest: compound 4; then compound 3; then compound 1. At a limit, above all of these: compound 2.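

In this assay, piperidin-1-yl on an aromatic carbon, para to a large group, puts a non-aromatic ring at this position and gives a 4.7-fold lower number from compound 3 to compound 4 (0.67 log units; beyond the scatter) and a 10-fold lower number from compound 1 to compound 4 (1.00 log units; beyond the scatter). The 1H-pyrrol-2-yl of compound 3 therefore no longer marks the low end at this position, and compound 4 has the lowest number of the set, with all its steps beyond the scatter. The widest step is an at least 26-fold lower number from compound 2 to compound 4 (1.41 log units; beyond the scatter), and it starts from an entry for compound 2 that is a limit and not a number: the limit of > 1 h in this assay, at which 1 of the 4 values shown sits.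

These compounds cannot tell whether the low number goes with the non-aromatic ring itself or with its nitrogen on the aromatic carbon. A cyclohexyl group, with carbon in place of that nitrogen, would separate the two.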